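The source may hold more compounds than are shown below. What is called first, only, known or untested is meant among the compounds shown, and "the series" means these compounds.

Measured so far:
compound 1, `CCOc1ccc(C2CC2C(=O)NNC(=O)c2ccncc2)cc1` — > 100000 nM in a functional assay on PC-3 cells (Homo sapiens) for inhibition, read by MTT assay, with a stated time of 72 h; a lower number here means a stronger inhibitor, a higher number a weaker inhibitor
compound 2, `COc1ccc(C2CC2C(=O)NNc2nncc3ccccc23)cc1` — 64000 nM in this assay

Among the compounds with values here, the value given for compound 1 is a limit of this assay rather than a number, and it is the only such value here (the limit of > 100000 nM in this assay, at which 1 of the 2 values shown sits). Within the data shown here, compound 2 therefore stands alone as the single measured number in this assay, and a high number it is: compound 2 counts as a weak inhibitor.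

Compound 3, `O=C(NNc1nncc2ccccc12)C1CC1c1ccc(OCC(F)(F)F)cc1`, shares the core of compound 2 and differs from it in one place: trifluoromethyl in place of hydrogen on a saturated chain carbon bound to an oxygen on an aromatic ring. Among the measured compounds shown here, no step between measured compounds is recorded, so there is nothing here to say how such a change moves the read-out. The expectation for the step from compound 2 to compound 3 is therefore a 1.2-fold lower number from compound 2 to compound 3 (0.07 log units; within the scatter), that is, nothing beyond the scatter of repeated measurements. Compound 3 is expected to give about 55000 nM, within a range from 15000 nM to 160000 nM.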

Compound 3, half-maximal inhibitory concentration: 67000 nM
Estimate against measurement, compound 3: 1.2-fold (0.09 log units) below; low and high end bracket the measured number.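

Within the data shown here, this is the first step recorded at this position, and it is small: in this assay, trifluoromethyl in place of hydrogen on a saturated chain carbon bound to an oxygen on an aromatic ring comes with a 1.0-fold higher number from compound 2 to compound 3 (0.02 log units; within the scatter). Methoxy and 2,2,2-trifluoroethoxy therefore cannot be told apart in this read-out, and the larger group leaves compound 3 a weak inhibitor, as compound 2 is. Nothing given here accounts for how little the number moves.

Going by these compounds, whether any group at this position can shift the number beyond the scatter stays open, as this single pair cannot show how an amine, a hydroxyl or a longer chain such as butoxy would behave. Compound 1 differs from both compounds in more than one place, so it does not help to settle this.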